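Methyl to Trifluoromethyl on a Shared Core

The source may report more compounds than this note shows. Statements on the series, on what has been measured and on what is new or still open speak of the compounds shown alone.

Of the compounds shown here, three have been measured in a functional assay on A549 cells (Homo sapiens) for inhibition, read by MTT assay, with a stated time of 72 h; a higher number here means a weaker inhibitor, a lower number a stronger inhibitor. Compound 3 `Cc1nc(N(C)C(=O)NC(=O)c2ccc(Cl)cc2Cl)sc1C(=O)N/N=C/c1ccc(C(F)(F)F)cc1` gives 30.2 ug/mL, and compound 1 `CN(C(=O)NC(=O)c1ccc(Cl)cc1Cl)c1nc(C(F)(F)F)c(C(=O)N/N=C/c2ccc(C(F)(F)F)cc2)s1` gives 9.4 ug/mL. The change from compound 3 to compound 1 is trifluoromethyl in place of methyl on an aromatic carbon, and it made a 3.2-fold lower number from compound 3 to compound 1 (0.51 log units; beyond the scatter). Compound 2 `Cc1nc(N(C)C(=O)NC(=O)c2c(F)cccc2F)sc1C(=O)N/N=C/c1cc(C(F)(F)F)cc(C(F)(F)F)c1` gives 13 ug/mL in this assay; its value and that of compound 1 lie within the scatter of each other, while compound 3 gives a higher number. The difference between the cores of compound 2 and compound 3 is not broken down here. Compound 4 `CN(C(=O)NC(=O)c1c(F)cccc1F)c1nc(C(F)(F)F)c(C(=O)N/N=C/c2cc(C(F)(F)F)cc(C(F)(F)F)c2)s1` is not yet measured; it differs from compound 2 by trifluoromethyl in place of methyl on an aromatic carbon, the same change, at the same place, as from compound 3 to compound 1. Because the earlier change gave a 3.2-fold lower number from compound 3 to compound 1 (0.51 log units; beyond the scatter), a comparable step, a 2.9-fold lower number from compound 2 to compound 4 (0.46 log units; beyond the scatter), is expected. Compound 4 is therefore estimated at 4.5 ug/mL, most likely between 2 ug/mL and 11 ug/mL.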

Compound 4, half-maximal inhibitory concentration: 17.3 ug/mL
Compound 4: the middle estimate sits 3.8-fold (0.58 log units) below what was measured; the measured number lies above the stated range.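

In this assay, putting trifluoromethyl in place of methyl on the second core did not repeat the earlier drop, giving a 1.3-fold higher number from compound 2 to compound 4 (0.12 log units; within the scatter). The step seen on one core therefore did not carry over to the other, and the two steps differ: the same change on two cores in this assay, a 3.2-fold lower number (0.51 log units; beyond the scatter) from compound 3 to compound 1 and a 1.3-fold higher number (0.12 log units; within the scatter) from compound 2 to compound 4, 4.3-fold (0.63 log units) apart, beyond the scatter of two such steps. This shows that the effect of the change depends on the rest of the molecule here, but it does not show which of the parts that differ between the two cores is responsible.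

Two pairs cannot show how the same change would behave on a third core. Also open, going by these compounds, is what other groups at this place, such as an ethyl group, a chlorine atom or an amine, would do.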